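Trichlorophenyl for Methoxyphenyl in a Weak Series

The source may hold more compounds than are shown below. What is called first, only, known or untested is meant among the compounds shown, and "the series" means these compounds.

Measured compounds:
compound 1 `N#CC1=C(N)Oc2c(c3nc4ccccc4nc3c3ccccc23)C12C(=O)N(Cc1cnnn1-c1ccc(S(N)(=O)=O)cc1)c1ccccc12`, > 50000 nM
compound 2 `Cc1ccc(-n2nncc2CN2C(=O)C3(C(C#N)=C(N)Oc4c3c3nc5ccccc5nc3c3ccccc43)c3ccccc32)c(C)c1`, > 50000 nM
compound 3 `COc1ccccc1-n1nncc1CN1C(=O)C2(C(C#N)=C(N)Oc3c(N)cc4nc5ccccc5nc4c32)c2ccccc21`, 28900 nM

In a functional assay on MCF7 cells (Homo sapiens) for antiproliferative activity, read by MTT assay, with a stated time of 48 h (a higher number here means a weaker inhibitor, a lower number a stronger inhibitor), compound 3 gives 28900 nM. Among the compounds with values here, that is the only actual number in this set. The value of compound 1 is a limit of the assay rather than a number. The value of compound 2 is likewise a limit. Within the data shown here, both sit at the limit of > 50000 nM in this assay, at which 2 of the 3 values shown sit, so the one measured step, a step that the two limits leave unreadable from compound 1 to compound 2, cannot be read, and no measured step speaks to the change now considered.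

Compound 4 `N#CC1=C(N)Oc2c(N)cc3nc4ccccc4nc3c2C12C(=O)N(Cc1cnnn1-c1c(Cl)cc(Cl)cc1Cl)c1ccccc12` differs from compound 3 in one place: 2,4,6-trichlorophenyl in place of 2-methoxyphenyl on an aromatic nitrogen. Compounds 1 and 2 carry other groups on the same aromatic nitrogen and show that such swaps can leave a compound at the limit, but they give no readable size or direction, and nothing shows how the 2,4,6-trichlorophenyl group itself behaves here.

Among the measured compounds shown here, with no usable step to build on, the expectation for compound 4 is a value close to that of compound 3, that is a step of a 1.0-fold higher number from compound 3 to compound 4 (0.02 log units; within the scatter), with a real chance that only a limit is reported. The estimate for compound 4 in this assay is 30000 nM, with a range from 9000 nM to 60000 nM.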

Compound 4, half-maximal inhibitory concentration: 37800 nM
Compound 4: the middle estimate sits 1.3-fold (0.10 log units) below what was measured; the measured number falls inside the stated range.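

In this assay, within the data shown here, replacing 2-methoxyphenyl with 2,4,6-trichlorophenyl on the aromatic nitrogen gives a 1.3-fold higher number from compound 3 to compound 4 (0.12 log units; within the scatter), the first readable step at this position, and so the two compounds cannot be told apart. On this core, then, a ring with three chlorine atoms and no hydrogen-bond acceptor can stand in for a ring with one methoxy group and one acceptor, and the read-out stays a measured number with no shift beyond the scatter. Compound 1 and compound 2 give only a limit of the assay and not a number, so the step between them cannot be read and offers no size to set beside this one: the limit of > 50000 nM in this assay, at which 2 of the 4 values shown sit.

Two different rings that give no separable result do not show that this position is insensitive to every change, since both belong to a single weak pair and the data give no reason for the small step. On these data alone, it remains open whether a ring carrying an amine or a carboxylic acid, or a longer chain in place of the ring, would move the number beyond the scatter on this core.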